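Methoxy in place of bromo: compound 3

This account rests on a few compounds, and the source may have more. Where it says the series, first, only, none or still open, it means among the compounds named here.

Among the compounds with values here, compound 2 `CCCNC(=O)c1cc(Oc2ccc(NC(=O)c3cc4cccnc4n(-c4ccc(Br)cc4)c3=O)cc2)ccn1` gives 530 nM in a functional assay on HT-29 cells (Homo sapiens) for antiproliferative activity, read by MTT assay, with a stated time of 72 h (on this read-out lower numbers stand for stronger inhibition and higher numbers for weaker inhibition), the highest of the two numbers so far, while compound 1 `CCCNC(=O)c1cc(Oc2ccc(NC(=O)c3cc4cccnc4n(-c4ccccc4)c3=O)cc2)ccn1` gives 98 nM. Within the data shown here, the only measured step, a 5.4-fold higher number from compound 1 to compound 2 (0.73 log units; beyond the scatter), bromo in place of hydrogen on an aromatic carbon, moved the number beyond the scatter. Compound 3 `CCCNC(=O)c1cc(Oc2ccc(NC(=O)c3cc4cccnc4n(-c4ccc(OC)cc4)c3=O)cc2)ccn1` carries the change (methoxy in place of bromo on an aromatic carbon), para to a large group; read one bond further out, 4-bromophenyl to 4-methoxyphenyl. Among the measured compounds shown here, no measured step replaces bromo by methoxy, so the step from compound 1 to compound 2 bears on it only in showing that a substituent at this place can move the number, not whether methoxy behaves like bromo or like hydrogen. Compound 3 is expected to fall between the two measured numbers, the step being a 2.1-fold lower number from compound 2 to compound 3 (0.33 log units; beyond the scatter). The estimate for compound 3 is 250 nM, with a range from 90 nM to 700 nM.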

Compound 3, half-maximal inhibitory concentration: 1560 nM
Compound 3: the middle estimate sits 6.2-fold (0.80 log units) below what was measured; measured number outside the range, above it.
By their numbers in this assay, from the lowest: compound 1; then compound 2; then compound 3.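

In this assay, replacing bromo with methoxy gives a 2.9-fold higher number from compound 2 to compound 3 (0.47 log units; beyond the scatter), and methoxy in place of hydrogen gives a 16-fold higher number from compound 1 to compound 3 (1.20 log units; beyond the scatter), so methoxy neither matches hydrogen nor falls short of bromo at this place. Both substituents, on an aromatic carbon para to a large group, move the number the same way from hydrogen, and none of the three compounds goes against this, with compound 1 keeping the lowest number. Nothing available accounts for the order hydrogen, bromo, methoxy.

With only two substituents set against hydrogen, the compounds shown do not tell whether any group here can match hydrogen or whether the number tracks the size of the group. A fluoro, a hydroxy, an amine or a carboxylic acid at this place would test both questions.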